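A few compounds are considered here, and "the series" means these few. Any claim that something is new, unique, unknown or untested is made for them only; others in the source may bear on it.

In a physicochemical assay for solubility, read by HPLC, in phosphate buffer, at pH 6.5 (on this read-out lower numbers stand for lower solubility and higher numbers for higher solubility), compound 1 `COC(=O)C1=C(C)NC(c2nccs2)=NC1(C)c1ccc(F)cc1` gives 22 ug/mL. Compound 3 `COC(=O)C1=C(C)NC(c2nccs2)=NC1(C)c1ccc(Cl)cc1` gives 14 ug/mL, and the chloro for fluoro exchange amounts to a 1.6-fold lower number from compound 1 to compound 3 (0.20 log units; within the scatter). Compound 2 `COC(=O)C1=C(C)NC(c2nccs2)=N[C@]1(C)c1ccc(F)cc1` gives 178 ug/mL, which makes an 8.1-fold higher number from compound 1 to compound 2 (0.91 log units; beyond the scatter). Among the compounds with values here, the one difference behind that step is the fact that one of compounds 1 and 2 is drawn with a defined configuration and the other without, at the place where they differ. Compound 1 therefore sits at the low end of these numbers together with compound 3, and well short of compound 2.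

Compound 4 `COC(=O)C1=C(CN2CCC(O)CC2)NC(c2nccs2)=NC1(C)c1ccc(F)cc1` differs from compound 1 at a site that neither measured step touches: 4-hydroxypiperidin-1-yl in place of hydrogen on a saturated chain carbon bound to a double-bonded ring carbon. In other words, methyl becomes (4-hydroxypiperidin-1-yl)methyl. The two measured steps therefore give no direct reading on this change and only set a scale. Within the data shown here, the halogen exchange stays within the scatter, while the largest step so far is the one to compound 2, an 8.1-fold higher number from compound 1 to compound 2 (0.91 log units; beyond the scatter). Among the measured compounds shown here, the direction assumed here is upward, and it is an expectation from the structural change alone, with no measured step at this site to support it. The expected size is close to that largest step, estimated as a 5.5-fold higher number from compound 1 to compound 4 (0.74 log units; beyond the scatter), with wide uncertainty. For compound 4 the expected value in this assay is 120 ug/mL, with an estimated range of 25 ug/mL to 600 ug/mL.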

Compound 4, solubility: 593 ug/mL
For compound 4 the middle estimate is 4.9-fold (0.69 log units) below the measured one, within the range that was stated.
By their numbers in this assay, from the lowest: compounds 3 and 1 (each within the scatter of the next); then compound 2; then compound 4.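

Going from methyl to (4-hydroxypiperidin-1-yl)methyl on the carbon bound to a double-bonded ring carbon gives, in this assay, a 27-fold higher number from compound 1 to compound 4 (1.43 log units; beyond the scatter), the largest step in the series and larger than an 8.1-fold higher number from compound 1 to compound 2 (0.91 log units; beyond the scatter). Within the data shown here, this site, untouched by the earlier compounds, takes a six-membered non-aromatic ring with a hydroxyl on it without any loss on this read-out, and the stereocentre is drawn without a configuration in both compounds of the step, so the step does not rest on a difference in drawing. Nothing available bears on why this exchange raises the number.

The compounds shown leave open which part of the entering group carries the step, the hydroxyl, the ring nitrogen or the ring as a whole, a question that a plain piperidin-1-yl, a morpholin-4-yl or a dimethylamino group on the same chain carbon would separate. Also open, going by these compounds, is whether a defined configuration at the stereocentre, as drawn in compound 2, adds to this change when both are present in one compound.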